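A Second Fluorine on the Benzoyl Ring

This account rests on a few compounds, and the source may have more. Where it says the series, first, only, none or still open, it means among the compounds named here.

Measured compounds:
compound 1 `[O-][S+](CCNC1CCN(Cc2ccc(F)cc2)CC1)C(c1ccc(F)cc1)c1ccc(F)cc1` — 26.5 nM
compound 2 `O=C(c1ccc(F)cc1)N1CCC(NCCSC(c2ccc(F)cc2)c2ccc(F)cc2)CC1` — 32.1 nM

In an assay on membranes from Cortex for displacement of a labelled ligand from Sigma non-opioid intracellular receptor 1 (Cavia porcellus), read by scintillation counting, with a stated time of 120 min (on this read-out higher numbers stand for weaker inhibition and lower numbers for stronger inhibition), compound 2 gives 32.1 nM and compound 1 gives 26.5 nM; the two numbers sit within the scatter of each other, so neither can be separated from the other. Compound 3 `O=C(c1ccc(F)cc1F)N1CCC(NCCSC(c2ccc(F)cc2)c2ccc(F)cc2)CC1` differs from compound 2 in one spot: fluoro in place of hydrogen on an aromatic carbon. For the measured compounds named here, no measured pair shows what such a change does here, so in this assay no step beyond the scatter is expected, in either direction. Compound 3 is estimated at 30 nM, between 12 nM and 80 nM, an expected step of a 1.1-fold lower number from compound 2 to compound 3 (0.03 log units; within the scatter).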

Compound 3, inhibition constant: 20.6 nM
Compound 3: middle estimate off by 1.5-fold (0.16 log units), on the high side; the measured number falls inside the stated range.
By their numbers in this assay, from the lowest: compounds 3, 1 and 2 (each within the scatter of the next).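

In this assay there is a 1.6-fold lower number from compound 2 to compound 3 (0.19 log units; within the scatter) on going from 4-fluorophenyl to 2,4-difluorophenyl. For the compounds shown here, this is the first measured pair for this change, and it shows that a fluoro ortho to a large group on this ring leaves the binding read-out indistinguishable from that of the parent compound. Nothing measured here gives a reason for this result.

From the compounds shown here alone, whether a larger group at this same carbon, such as methoxy or trifluoromethyl, would give a step beyond the scatter stays open. The same question holds for an amine there.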